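Isopropyl for cyclopentyl on the aminopyrimidine nitrogen

The source may report more compounds than this note shows. Statements on the series, on what has been measured and on what is new or still open speak of the compounds shown alone.

Measured so far in an in vitro ADME assay on microsomes from liver (Homo sapiens) for metabolic stability; on this read-out higher numbers stand for fast clearance and lower numbers for slow clearance:
- compound 1, `CC(C)Nc1nccc(-c2cn[nH]c2)n1`: 0.021 mL/min/kg
- compound 2, `CC(C)Nc1nccc(-c2c[nH]nc2C2CCCCO2)n1`: 0.021 mL/min/kg
- compound 3, `c1cc(-c2c[nH]nc2C2CCCOC2)nc(NC2CCCC2)n1`: 0.089 mL/min/kg

Compound 3 gives the highest number of the three, beyond the scatter from both compound 1 and compound 2, which sit within the scatter of each other. Among the compounds with values here, the one step measured, no change at the digits printed from compound 1 to compound 2 (within the scatter), shows that adding oxan-2-yl on an aromatic carbon left the clearance unchanged.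

Compound 4, `CC(C)Nc1nccc(-c2c[nH]nc2C2CCCOC2)n1`, has not yet been measured. It differs from compound 3 in one place: isopropyl in place of cyclopentyl on a nitrogen on an aromatic ring. Within the data shown here, no measured step isolates this exchange; compound 3 is the only cyclopentylamino compound, and compound 1 and compound 2 carry isopropylamino. Among the measured compounds shown here, compound 4 and compound 2 differ only in the oxanyl group, and both of the isopropylamino compounds measured so far sit at the low end. On that basis compound 4 is expected to move down from compound 3, with the estimated step of a 2.5-fold lower number from compound 3 to compound 4 (0.41 log units; beyond the scatter), though the pull toward compound 2 remains uncertain. The estimate for compound 4 in this assay is 0.035 mL/min/kg, with a range from 0.015 mL/min/kg to 0.08 mL/min/kg.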

Compound 4, clearance: 0.034 mL/min/kg
Estimate against measurement, compound 4: 1.0-fold (0.01 log units) above, within the range that was stated.
By their numbers in this assay, from the lowest: compounds 1, 2 and 4 (each within the scatter of the next); then compound 3.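

In this assay, within the data shown here, the exchange of cyclopentylamino for isopropylamino now has a measured step of its own, a 2.6-fold lower number from compound 3 to compound 4 (0.42 log units; beyond the scatter), read with oxan-3-yl on the aromatic carbon; the earlier compounds offered no single-place comparison at this nitrogen. With isopropyl held on the nitrogen, the oxanyl group separates nothing beyond the scatter: the comparison of oxan-3-yl with oxan-2-yl gives a 1.6-fold higher number from compound 2 to compound 4 (0.21 log units; within the scatter), and the comparison of oxan-3-yl with hydrogen gives a 1.6-fold higher number from compound 1 to compound 4 (0.21 log units; within the scatter). The compounds shown offer no evidence on why the read-out responds to the exchange at this nitrogen.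

As far as these compounds go, the step at the nitrogen rests on a single pair, so it remains open whether the same exchange would give a similar step with oxan-2-yl or hydrogen on the aromatic carbon. From the compounds shown here alone, it also remains open whether the higher number of compound 3 follows the ring itself or the larger carbon count of cyclopentyl, a question that cyclobutyl or an open pentyl chain on the same nitrogen would address.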